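Ethoxy for propyl on the butoxy chain of compound 1

The source may hold more compounds than are shown below. What is called first, only, known or untested is meant among the compounds shown, and "the series" means these compounds.

- compound 1 `CCCCOc1ccc2c(N3CCNCC3)cc(=O)oc2c1C`: 5030 nM
- compound 2 `O=c1cc(N2CCNCC2)c2ccc(OCc3cccnc3)cc2o1`: 18900 nM

Within the data shown here, in a functional assay on a cell-free system (plasma, Homo sapiens) for inhibition, with Plasma (Rattus norvegicus) as the target (a higher number here means a weaker inhibitor, a lower number a stronger inhibitor), compound 1 gives 5030 nM, the lower of the two numbers so far. Compound 2 gives 18900 nM, higher than compound 1 by more than the scatter. These two compounds differ in more than one place, so no single change can be read from them.

Compound 3 `CCOCOc1ccc2c(N3CCNCC3)cc(=O)oc2c1C` is not yet measured. It carries ethoxy in place of propyl on a saturated chain carbon bound to an oxygen on an aromatic ring, which turns butoxy into ethoxymethoxy. Among the measured compounds shown here, the series offers no measured precedent for this change. The estimated step of a 1.5-fold higher number from compound 1 to compound 3 (0.17 log units; within the scatter) is a small one towards a higher number, expected to stay within the scatter. For compound 3 the expected value is 7500 nM, with an estimated range of 2800 nM to 20000 nM.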

Compound 3, half-maximal inhibitory concentration: 1900 nM
Compound 3: the middle estimate sits 3.9-fold (0.60 log units) above what was measured; measured number outside the range, below it.
By their numbers in this assay, from the lowest: compound 3; then compound 1; then compound 2.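

In this assay, this position on the chain responds to a change of atom type: ethoxy in place of propyl, on a saturated chain carbon bound to an oxygen on an aromatic ring, gives a 2.6-fold lower number from compound 1 to compound 3 (0.42 log units; beyond the scatter). Both groups count 3 heavy atoms, so the step goes with one carbon giving way to an oxygen and butoxy becoming ethoxymethoxy, not with a change in the heavy-atom count of the group. Among these compounds, this is the first pair that differs in one place, and nothing measured so far accounts for the step.

One pair cannot show whether the gain depends on the chain oxygen itself or on where it sits in the chain. A longer chain such as hexyl, or an amine at this same place, remains an open comparison, and compound 2 differs in too many places to settle either.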